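A Chlorophenyl Carbamoylamino Analogue Tested for Growth Inhibition

This account rests on a few compounds, and the source may have more. Where it says the series, first, only, none or still open, it means among the compounds named here.

Compound 1 `COc1cc(NC(C)CCCNC(=O)NNC(=O)Nc2cc(C(F)(F)F)cc(C(F)(F)F)c2)c2ncccc2c1` gives 17000 nM in a functional assay on HeLa cells (Homo sapiens) for inhibition, read by MTT assay, with a stated time of 72 h; a higher number here means a weaker inhibitor, a lower number a stronger inhibitor.
Compound 2 `COc1cc(NC(C)CCCNC(=O)NNC(=O)Nc2ccc(Br)cc2)c2ncccc2c1` gives 101000 nM in this assay.
Compound 3 `COc1cc(NC(C)CCCNC(=O)Nc2ccc(O)cc2)c2ncccc2c1` gives 70000 nM in this assay.

Compound 3 stands second highest of the three numbers: its nearest neighbour is compound 2, and the step of a 1.4-fold lower number from compound 2 to compound 3 (0.16 log units; within the scatter) lies within the scatter, whereas compound 1 lies furthest away, with a lower number beyond the scatter. Compound 4 `COc1cc(NC(C)CCCNC(=O)NNC(=O)Nc2cccc(Cl)c2)c2ncccc2c1` differs from compound 3 by ((3-chlorophenyl)carbamoyl)amino in place of 4-hydroxyphenyl on an amide-type nitrogen. Among the compounds with values here, the one measured step that bears on this change is the near reverse of it, and because a 1.4-fold lower number from compound 2 to compound 3 (0.16 log units; within the scatter) was within the scatter, no step beyond the scatter is expected in this assay from the change alone; compound 1 with 17000 nM shows only that such a group can accompany a lower number. Compound 4 is therefore expected to give 50000 nM, with a range of 15000 nM to 150000 nM. The estimated step is a 1.4-fold lower number from compound 3 to compound 4 (0.15 log units; within the scatter).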

Compound 4, half-maximal inhibitory concentration: 44000 nM
Estimate against measurement, compound 4: 1.1-fold (0.06 log units) above, and the stated range covers the measured number.
By their numbers in this assay, from the lowest: compound 1; then compounds 4, 3 and 2 (each within the scatter of the next, the first and the last beyond it).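

Putting ((3-chlorophenyl)carbamoyl)amino in place of 4-hydroxyphenyl on the amide-type nitrogen gives a 1.6-fold lower number from compound 3 to compound 4 (0.20 log units; within the scatter) in this assay, so the two groups are not told apart at this position. The terminal aryl group does register: 3-chlorophenyl in place of 4-bromophenyl gives a 2.3-fold lower number from compound 2 to compound 4 (0.36 log units; beyond the scatter), a modest step and the first beyond the scatter between compounds differing in one place. Nothing measured here gives a reason for either step. That step alters both the halogen and its ring position, and the compounds shown do not separate the two. From the compounds shown here alone, how an amine or a carboxylic acid on that phenyl ring would read remains open.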